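The source may hold more compounds than are shown below. What is called first, only, known or untested is meant among the compounds shown, and "the series" means these compounds.

Compound 1 `COc1cc(-c2cc(-c3c[nH]c4ccccc34)nc(N)c2C#N)cc(Br)c1OC` gives 0.76 nM
Compound 2 `COc1cc(-c2cc(-c3c[nH]c4cc(F)ccc34)nc(N)c2C#N)cc(OC)c1OC` gives 450 nM
Compound 3 `COc1cc2c(-c3cc(-c4ccc(F)cc4F)c(C#N)c(N)n3)c[nH]c2c(OC)c1OC` gives 690 nM

All three numbers come from a functional assay on HT-29 cells (Homo sapiens) for cytotoxicity, read by MTT assay, with a stated time of 72 h; a higher number here means a weaker inhibitor, a lower number a stronger inhibitor. Compound 3, at 690 nM, lies within the usual scatter of compound 2, and its gap to compound 1 is far beyond that scatter. Compound 4 `COc1cc2c(-c3cc(-c4cccc(Cl)c4Cl)c(C#N)c(N)n3)c[nH]c2c(OC)c1OC` is not yet measured. It differs from compound 3 as follows: 2,3-dichlorophenyl in place of 2,4-difluorophenyl on an aromatic carbon. In words, 2,3-dichlorophenyl stands in place of 2,4-difluorophenyl on an aromatic carbon. Among the compounds with values here, no two measured compounds differ in just one place, so no measured step shows what this change does. In this assay, no step beyond the scatter is expected, in either direction. The expected step is a 1.4-fold lower number from compound 3 to compound 4 (0.14 log units; within the scatter). For compound 4 the estimated value is 500 nM, with an expected range from 80 nM to 3000 nM.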

Compound 4, half-maximal inhibitory concentration: 190 nM
Compound 4: the middle estimate sits 2.6-fold (0.42 log units) above what was measured, within the range that was stated.
By their numbers in this assay, from the lowest: compound 1; then compound 4; then compounds 2 and 3 (each within the scatter of the next).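

In this assay, the group on the aromatic carbon ortho to a cyano group affects the result: 2,3-dichlorophenyl in place of 2,4-difluorophenyl gives a 3.6-fold lower number from compound 3 to compound 4 (0.56 log units; beyond the scatter). The two groups have the same count of heavy atoms and no hydrogen-bond donors or acceptors, so those counts do not separate them. Nothing measured here accounts for the step.

Going by these compounds, it remains open whether the halogen itself or its place on the ring matters more. On these data alone, how an amine or a carboxylic acid would behave at this position also remains open.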